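A few compounds are considered here, and "the series" means these few. Any claim that something is new, unique, unknown or untested is made for them only; others in the source may bear on it.

Three compounds share one core and differ only in the aromatic ring that sits on a saturated ring carbon. Compound 1 `CC(=O)N1CCC(C(=O)N2CC[C@H](C(=O)N(C)Cc3cc(C(F)(F)F)cc(C(F)(F)F)c3)[C@@H](c3ccc(C)cc3)C2)CC1` carries a 4-methylphenyl there, and in an assay on IM-9 cells for displacement of a labelled ligand from Substance-P receptor (Homo sapiens), read by scintillation counting, with a stated time of 30 min (on this read-out lower numbers stand for stronger inhibition and higher numbers for weaker inhibition), compound 1 gives 0.18 nM. Compound 2 `CCc1ccccc1[C@H]1CN(C(=O)C2CCN(C(C)=O)CC2)CC[C@@H]1C(=O)N(C)Cc1cc(C(F)(F)F)cc(C(F)(F)F)c1` carries a 2-ethylphenyl, and compound 2 gives 0.064 nM. Compound 3 `CC(=O)N1CCC(C(=O)N2CC[C@H](C(=O)N(C)Cc3cc(C(F)(F)F)cc(C(F)(F)F)c3)[C@@H](c3ccccc3C)C2)CC1` carries a 2-methylphenyl, and compound 3 gives 0.032 nM, the lowest of the three numbers. Moving the methyl to a different ring position brought a 5.6-fold lower number from compound 1 to compound 3 (0.75 log units; beyond the scatter), and the step of a 2.8-fold lower number from compound 1 to compound 2 (0.45 log units; beyond the scatter) pointed the same way. By contrast, a 2.0-fold lower number from compound 2 to compound 3 (0.30 log units; within the scatter) lies within the scatter, so over that small span the size of the group at that position made no clear difference.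

Compound 4 `CC(=O)N1CCC(C(=O)N2CC[C@H](C(=O)N(C)Cc3cc(C(F)(F)F)cc(C(F)(F)F)c3)[C@@H](c3ccccc3C(C)C)C2)CC1` extends the same idea: isopropyl in place of methyl on an aromatic carbon. Among the compounds with values here, the only measured step that bears on this change, from compound 2 to compound 3, stayed within the scatter, so a further enlargement at the same position is expected to shift this assay little, perhaps slightly toward a higher number, but not clearly beyond the scatter. Compound 4 is therefore estimated to give 0.05 nM, with a likely range from 0.015 nM to 0.16 nM. That estimate corresponds to an expected step of a 1.6-fold higher number from compound 3 to compound 4 (0.19 log units; within the scatter).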

Compound 4, half-maximal inhibitory concentration: 0.21 nM
Compound 4: the middle estimate sits 4.2-fold (0.62 log units) below what was measured; measured number above the stated range.
By their numbers in this assay, from the lowest: compounds 3 and 2 (each within the scatter of the next); then compounds 1 and 4 (each within the scatter of the next).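

Enlarging the group on this aromatic carbon, ortho to a large group, is not free after all: in this assay the change from methyl to isopropyl brings a 6.6-fold higher number from compound 3 to compound 4 (0.82 log units; beyond the scatter) and so moves clearly beyond the scatter, unlike the earlier comparison of the 2-methylphenyl and 2-ethylphenyl compounds. The step of a 3.3-fold higher number from compound 2 to compound 4 (0.52 log units; beyond the scatter) confirms this, showing that the tolerance seen for those two smaller groups does not extend to isopropyl. The advantage of 2-methylphenyl over 4-methylphenyl also disappears with this group, since a 1.2-fold higher number from compound 1 to compound 4 (0.07 log units; within the scatter) leaves compound 1 and compound 4 indistinguishable, and no measurement shown accounts for this loss.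

From the compounds shown here alone, it remains open whether the larger number follows the branching of isopropyl or simply its carbon count, a question that an unbranched propyl chain at the same place would help to settle. Also unresolved is how groups containing atoms other than carbon, such as methoxy or chlorine, would compare at this place with methyl, ethyl and isopropyl.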